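Adding a second methoxy to compound 3

The source may report more compounds than this note shows. Statements on the series, on what has been measured and on what is new or still open speak of the compounds shown alone.

compound 1 `COc1cc(/C=C/C(=O)/C=C/c2cccs2)ccc1OCc1cn(CCOc2cc(=O)oc3ccccc23)nn1` gives 12%
compound 2 `COc1ccccc1/C=C/C(=O)/C=C/c1ccc(OCc2cn(CCCOc3cc(=O)oc4ccccc34)nn2)c(OC)c1` gives "not active" (no number reported)
compound 3 `COc1cccc(/C=C/C(=O)/C=C/c2ccc(OCc3cn(CCOc4cc(=O)oc5ccccc45)nn3)c(OC)c2)c1` gives 13%

All three compounds were tested in a functional assay on PC-3 cells (Homo sapiens) for inhibition, read by sulforhodamine B assay, with a stated time of 48 h, tested at 50 uM; a higher number here means more inhibition of growth at the concentration tested, a lower number less inhibition of growth. There, compound 3 gives 13% and stands level with compound 1, since the two values lie within the scatter of each other. Compound 2 was reported as "not active" (no number reported), without a number, so it offers no numerical comparison.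

The next compound is compound 4 `COc1ccc(/C=C/C(=O)/C=C/c2ccc(OCc3cn(CCOc4cc(=O)oc5ccccc45)nn3)c(OC)c2)cc1OC`. It differs from compound 3 by a single change: methoxy in place of hydrogen on an aromatic carbon. This turns 3-methoxyphenyl into 3,4-dimethoxyphenyl, with the new methoxy ortho to the existing methoxy group.

For the measured compounds named here, the one measured step that bears on this is a number 1 percentage points higher from compound 1 to compound 3 (within the scatter). That step put thiophen-2-yl and 3-methoxyphenyl in the same place, the group now being altered, and the exchange left the reading within the scatter. Going by the values given here, it is small, but it is only a single step, and no measured step adds a methoxy to this group. No shift beyond the scatter is therefore expected, in either direction.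

The expected step is a number 2 percentage points higher from compound 3 to compound 4 (within the scatter). For compound 4 the estimated value in this assay is 15%, with an expected range from 4% to 30%.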

Compound 4, percent growth inhibition at one concentration: 19%
Estimate against measurement, compound 4: 4 percentage points below, within the range that was stated.
By their numbers in this assay, from the lowest: compounds 1, 3 and 4 (each within the scatter of the next).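

In this assay, placing a methoxy on the aromatic carbon ortho to a methoxy group and para to a large group, which turns 3-methoxyphenyl into 3,4-dimethoxyphenyl, gives a number 6 percentage points higher from compound 3 to compound 4 (within the scatter), so this position accepts the added group without a shift beyond the scatter. The earlier compounds had shown this only for an exchange of the whole group, and the new compound extends that picture: with thiophen-2-yl replaced by 3,4-dimethoxyphenyl on the same chain carbon, the result is a number 7 percentage points higher from compound 1 to compound 4 (within the scatter), which leaves these two groups, like the earlier pair, not separated by this read-out. Nothing available explains these readings, and no supporting measurement accompanies them.

On these data alone, whether any other group at this aromatic carbon, such as an amine, a carboxylic acid or a longer chain like ethoxy, would move the reading beyond the scatter remains open. Also open, as far as these compounds go, is whether the same methoxy would behave in this way on the aromatic ring at the other end of the dienone chain, or in other cell lines.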